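Adding a chloro to compound 1

The compounds below may be only part of what the source reports. "The series", "measured", "known", "first", "only" and "open" are said of these compounds alone.

Measured so far in a physicochemical assay for solubility, read by HPLC; a lower number here means a less soluble compound, a higher number a more soluble compound (two compounds):
compound 1 `CN(C/C=C/c1ccc(Cl)cc1)Cc1cccc2ccoc12` gives 7400 ug/mL
compound 2 `CN(C/C=C/c1ccc(Br)cc1)Cc1cccc2ccoc12` gives 3900 ug/mL

Among the compounds with values here, compound 1 and compound 2 are the only measured compounds, and their numbers cannot be separated, so compound 1 stands level with compound 2 within the scatter. Compound 3 `CN(C/C=C/c1ccc(Cl)cc1Cl)Cc1cccc2ccoc12` keeps the core of compound 1 and carries one change (chloro in place of hydrogen on an aromatic carbon): chloro in place of hydrogen on an aromatic carbon. Within the data shown here, only one measured step exists (a 1.9-fold lower number from compound 1 to compound 2 (0.28 log units; within the scatter)), and it swaps bromo for chloro instead of adding a group. Among the measured compounds shown here, no measured step adds a chloro, so the evidence is thin. The expected direction leans on compound 2 alone, and the expected size is about that of the scatter. For compound 3, an estimated 1.9-fold lower number from compound 1 to compound 3 (0.27 log units; within the scatter) is expected in this assay (no large change). Compound 3 is estimated at 4000 ug/mL (expected range 1500 ug/mL to 9000 ug/mL).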

Compound 3, solubility: 7200 ug/mL
Beside the measured number, compound 3's estimate is 1.8-fold (0.26 log units) below it; the measured number falls inside the stated range.
By their numbers in this assay, from the lowest: compounds 2, 3 and 1 (each within the scatter of the next).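

In this assay, chloro in place of hydrogen on an aromatic carbon, ortho to a large group and meta to a chloro group, gives a 1.0-fold lower number from compound 1 to compound 3 (0.01 log units; within the scatter) and so cannot be told apart from no change at all. Compound 2 showed only a swap of one halogen for another at an existing site, whereas compound 3 shows that a group can be added at this new position with the number staying level with that of compound 1 within the scatter. Nothing measured here bears on why the number holds at this position.

A single chloro is the only addition shown at this position, so it remains open whether a methoxy group, an amine or a carboxylic acid placed there would also stay within the scatter. As far as these compounds go, it also remains open whether chloro added elsewhere on the same ring would give a similar result.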